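Moving a Fluorine Around a Pyridine: Exposure Expectations

The source may hold more compounds than are shown below. What is called first, only, known or untested is meant among the compounds shown, and "the series" means these compounds.

Compound 1 `O=C(Nc1ccc(F)c(-c2nc3ncc(-c4cc(F)ccc4F)cc3[nH]2)c1)N1CCCC1` and compound 2 `O=C(Nc1ccc(F)c(-c2nc3ncc(-c4cncc(F)c4)cc3[nH]2)c1)N1CCCC1` share one core. In an ADME assay on the whole organism (Mus musculus, strain Swiss Webster) for pharmacokinetics, read by LC-MS, at a dose of 50 mg/kg by the oral route (a lower number here means less compound in the circulation, a higher number more compound in the circulation at the dose given), compound 1 gives 2800 nM, while compound 2 gives 1070 nM, the lower of the two numbers, separated by a 2.6-fold lower number from compound 1 to compound 2 (0.42 log units; beyond the scatter). Compound 3 `O=C(Nc1ccc(F)c(-c2nc3ncc(-c4cccnc4F)cc3[nH]2)c1)N1CCCC1` keeps the same atoms as compound 2 but joins them differently: 2-fluoropyridin-3-yl in place of 5-fluoropyridin-3-yl on an aromatic carbon. Among the compounds with values here, no measured step exchanges one fluoropyridine for another, so a 2.6-fold lower number from compound 1 to compound 2 (0.42 log units; beyond the scatter) bears on it only loosely. For compound 3 a step within the scatter, a 1.2-fold higher number from compound 2 to compound 3 (0.08 log units; within the scatter), is expected. Compound 3 is therefore estimated at 1300 nM, within 500 nM to 3500 nM.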

Compound 3, maximal plasma concentration: 25600 nM
Beside the measured number, compound 3's estimate is 20-fold (1.29 log units) below it; the whole stated range lies below it.
By their numbers in this assay, from the lowest: compound 2; then compound 1; then compound 3.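

At this position, rearranging the same atoms matters far more than the earlier exchange suggested: in this assay, 2-fluoropyridin-3-yl in place of 5-fluoropyridin-3-yl gives a large change (a 24-fold higher number from compound 2 to compound 3 (1.38 log units; beyond the scatter)). The 2-fluoropyridin-3-yl group also exceeds 2,5-difluorophenyl (a 9.1-fold higher number from compound 1 to compound 3 (0.96 log units; beyond the scatter)), so a pyridine here does not in itself go with the lower number, as compound 2 alone had suggested. No evidence is available that accounts for this jump. Still open, from the compounds shown here alone, is whether 2-chloropyridin-3-yl or 2-methoxypyridin-3-yl would keep the higher number.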